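Swapping Cyclopentyl for a Fluoropyridinyl on the Alkyne

This account rests on a few compounds, and the source may have more. Where it says the series, first, only, none or still open, it means among the compounds named here.

Compound 1 `C[C@@H](NC(=O)c1ccc(C#Cc2ccccc2F)cn1)C(C)(C)O`: 29.6%
Compound 2 `C[C@@H](NC(=O)c1ccc(C#Cc2cccnc2)cn1)C(C)(C)O`: 25.9%
Compound 3 `C[C@@H](NC(=O)c1ccc(C#CC2CCCC2)cn1)C(C)(C)O`: 14.8%

In an ADME assay on HEK293 cells for agonist activity at metabotropic glutamate receptor 5 (Rattus norvegicus), read by fluorescence and calcium flux (on this read-out higher numbers stand for larger maximal responses and lower numbers for smaller maximal responses), compound 3 gives the lowest maximal response of the three measured compounds, and its gaps to both others lie beyond the scatter. The unmeasured compound 4 `C[C@@H](NC(=O)c1ccc(C#Cc2cccc(F)n2)cn1)C(C)(C)O` differs from compound 3 in one place: 6-fluoropyridin-2-yl in place of cyclopentyl on a triple-bonded carbon. Among the compounds with values here, two measured steps bear on this change, namely a number 14.8 percentage points lower from compound 1 to compound 3 (beyond the scatter) and a number 11.1 percentage points lower from compound 2 to compound 3 (beyond the scatter); each put cyclopentyl in place of a six-membered aromatic ring on the triple-bonded carbon, and each lowered the response modestly. The change to compound 4 runs the other way, so a modest rise is expected: a number 12.2 percentage points higher from compound 3 to compound 4 (beyond the scatter). Compound 4 is therefore estimated to reach about 27%, expected between 17% and 37%.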

Compound 4, largest response reached (reported as efficacy), in percent of the reference or control that the assay uses: 8.3%
For compound 4 the middle estimate is 18.7 percentage points above the measured one; measured number outside the range, below it.
By their numbers in this assay, from the lowest: compounds 4 and 3 (each within the scatter of the next); then compounds 2 and 1 (each within the scatter of the next).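

In this assay an aromatic ring on the triple-bonded carbon is not enough for a larger response, with a number 6.5 percentage points lower from compound 3 to compound 4 (within the scatter) when 6-fluoropyridin-2-yl takes the place of cyclopentyl. Steps of a number 17.6 percentage points lower from compound 2 to compound 4 (beyond the scatter) and a number 21.3 percentage points lower from compound 1 to compound 4 (beyond the scatter) set this group apart from the other two aromatic groups, so which ring sits here matters, not merely that one does. Within the data shown here, nothing measured so far gives a reason for this. Still open, from the compounds shown here alone, is whether plain pyridin-2-yl, without the fluorine, would respond like compound 2 or like compound 4, which would show whether the fluorine or the place of the ring nitrogen goes with the low response.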